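The source may hold more compounds than are shown below. What is called first, only, known or untested is meant among the compounds shown, and "the series" means these compounds.

Measured so far in an in vitro assay on BaF3 cells for displacement of a labelled ligand from C-X-C chemokine receptor type 3 (Homo sapiens); a lower number here means a stronger inhibitor, a higher number a weaker inhibitor:

compound 1, `CC[C@H]1CN(c2ncc(C(=O)NC3CC3)nc2Cl)CCN1C1CCN(C(=O)c2ccc(Cl)nc2N)CC1` — 1.2 nM
compound 2, `CC[C@H]1CN(c2ncc(C(=O)NC3CC3)nc2C(F)(F)F)CCN1C1CCN(C(=O)c2ccc(Cl)nc2N)CC1` — 1.8 nM
compound 3, `CC[C@H]1CN(c2ncc(C(N)=O)nc2C)CCN1C1CCN(C(=O)c2ccc(Cl)nc2N)CC1` — 4 nM

Compound 3 gives the highest number of the three; compound 2 is nearest and compound 1 furthest, and both of those gaps lie beyond the scatter. Among the compounds with values here, the one measured step, a 1.5-fold higher number from compound 1 to compound 2 (0.18 log units; within the scatter), concerns the substituent on the aromatic carbon and stays within the scatter.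

Compound 4, `CC[C@H]1CN(c2ncc(C(=O)NC3CC3)nc2C)CCN1C1CCN(C(=O)c2ccc(Cl)nc2N)CC1`, has not been measured. It differs from compound 3 in one place: cyclopropyl in place of hydrogen on an amide-type nitrogen. Within the data shown here, no measured pair differs in exactly this way, so no step bears on it directly. What the data do show is that compound 1 and compound 2, which carry the cyclopropylcarbamoyl group, return lower numbers in this assay than compound 3, which carries the plain carbamoyl group; yet those two also differ from compound 3 on the aromatic carbon, so the comparison is not clean.

On that basis a modest move toward a lower number is expected, and compound 4 is estimated at 2 nM, with a range from 0.8 nM to 5 nM, meaning an expected step of a 2.0-fold lower number from compound 3 to compound 4 (0.30 log units; within the scatter).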

Compound 4, half-maximal inhibitory concentration: 1.9 nM
For compound 4 the middle estimate is 1.1-fold (0.02 log units) above the measured one; measured number inside the range.
By their numbers in this assay, from the lowest: compounds 1, 2 and 4 (each within the scatter of the next); then compound 3.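

In this assay, within the data shown here, the cyclopropyl on the amide-type nitrogen can now be read in a single change: the step shows a 2.1-fold lower number from compound 3 to compound 4 (0.32 log units; beyond the scatter), which is modest but beyond the scatter, so the link between the cyclopropylcarbamoyl group and a lower number no longer rests on compounds that also differ on the aromatic carbon. With cyclopropylcarbamoyl held in place, methyl, chloro and trifluoromethyl on the aromatic carbon are not told apart by this assay, as the steps show a 1.1-fold higher number from compound 2 to compound 4 (0.02 log units; within the scatter) and a 1.6-fold higher number from compound 1 to compound 4 (0.20 log units; within the scatter), both within the scatter. No measurement in hand gives a reason for either result.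

Going by these compounds, it remains open whether the step from carbamoyl to cyclopropylcarbamoyl keeps its size when chloro or trifluoromethyl, rather than methyl, sits on the aromatic carbon, and whether a methyl, an ethyl or a cyclobutyl on the amide-type nitrogen would serve as cyclopropyl does. Also open, on these data alone, is whether the aromatic carbon would tolerate a methoxy, a nitrile or plain hydrogen as it tolerates the three groups compared here.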